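Moving the methyl group of compound 3

This account rests on a few compounds, and the source may have more. Where it says the series, first, only, none or still open, it means among the compounds named here.

In an ADME assay on L02 cells (Homo sapiens) for cytotoxicity, read by MTT assay, with a stated time of 72 h (a higher number here means a weaker inhibitor, a lower number a stronger inhibitor), compound 1 `O=C(O)CCC(=O)OCCCCCCSc1ccc([N+](=O)[O-])c2nonc12` gives 1890 nM as the reference point. Compound 2 `O=C(CCC(=O)OCCCCCCSc1ccc([N+](=O)[O-])c2nonc12)Nc1ccccc1` gives 6490 nM on the same scale, and compound 3 `Cc1ccccc1NC(=O)CCC(=O)OCCCCCCSc1ccc([N+](=O)[O-])c2nonc12` gives 9490 nM in the same measurement. Compound 3 shares the upper end of these numbers with its nearest neighbour, the gap being a 1.5-fold higher number from compound 2 to compound 3 (0.17 log units; within the scatter) for the added methyl. Its furthest neighbour lies at a 5.0-fold higher number from compound 1 to compound 3 (0.70 log units; beyond the scatter) and the matching step without the methyl is a 3.4-fold higher number from compound 1 to compound 2 (0.54 log units; beyond the scatter) in the same direction.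

Compound 4 `Cc1ccc(NC(=O)CCC(=O)OCCCCCCSc2ccc([N+](=O)[O-])c3nonc23)cc1` has the same atoms joined differently, with 4-methylphenyl in place of 2-methylphenyl on an amide-type nitrogen. The methyl step bears most directly on this change, while the two larger steps concern replacing hydroxy and say little here. No 4-methylphenyl amide has a measured value yet. The expected change is a 1.2-fold lower number from compound 3 to compound 4 (0.07 log units; within the scatter) as estimated, so no step beyond the scatter is foreseen. In this assay the estimate for compound 4 is 8000 nM and the expected range runs from 4000 nM to 16000 nM on this reading.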

Compound 4, half-maximal inhibitory concentration: 7320 nM
For compound 4 the middle estimate is 1.1-fold (0.04 log units) above the measured one; low and high end bracket the measured number.
By their numbers in this assay, from the lowest: compound 1; then compounds 2, 4 and 3 (each within the scatter of the next).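

In this assay, exchanging 2-methylphenyl for 4-methylphenyl on the amide-type nitrogen gives a 1.3-fold lower number from compound 3 to compound 4 (0.11 log units; within the scatter), so these numbers do not separate the two methyl placements. Set against the phenyl amide, the methyl in its new place gives a 1.1-fold higher number from compound 2 to compound 4 (0.05 log units; within the scatter), so neither methylphenyl amide shown is separated from the phenyl amide. The amide with 4-methylphenyl still stands apart from the free acid, with a 3.9-fold higher number from compound 1 to compound 4 (0.59 log units; beyond the scatter), so all three amides shown differ from compound 1 beyond the scatter but not from one another.

Nothing measured here accounts for these steps. Open, going by these compounds, is whether 3-methylphenyl, 4-methoxyphenyl or 4-chlorophenyl on the same amide-type nitrogen would give a number beyond the scatter of compound 2 .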